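The source may hold more compounds than are shown below. What is called first, only, known or untested is meant among the compounds shown, and "the series" means these compounds.

In an ADME assay on NHDF cells (Homo sapiens) for cytotoxicity, read by MTT assay, with a stated time of 72 h (a higher number here means a weaker inhibitor, a lower number a stronger inhibitor), three compounds sharing one core have numbers. Compound 1 (`COc1cccc(/C=C2\CCC/C(=C\c3ccccc3Cl)C2=O)c1OC`) gives 44200 nM and compound 2 (`COc1cccc(/C=C2\CCC/C(=C\c3ccc(Cl)cc3)C2=O)c1OC`) gives 18600 nM while compound 3 (`COc1cccc(/C=C2\CCC/C(=C\c3cccc(Br)c3)C2=O)c1OC`) gives 23900 nM in the same assay. Among the measured compounds shown here, the only step beyond the scatter is modest: a 2.4-fold lower number from compound 1 to compound 2 (0.38 log units; beyond the scatter) in size. Compound 3 stands within the scatter of both others, as a 1.8-fold lower number from compound 1 to compound 3 (0.27 log units; within the scatter) and a 1.3-fold higher number from compound 2 to compound 3 (0.11 log units; within the scatter) show.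

The change to compound 4 (`COc1cccc(/C=C2\CCC/C(=C\c3cccc(O)c3)C2=O)c1OC`) is hydroxy in place of bromo on an aromatic carbon, meta to a large group (hydroxy in place of bromo on an aromatic carbon). The measured steps bear on this only indirectly, since they exchange chlorophenyl and bromophenyl groups and none brings in hydroxy. With so little movement among them, no step beyond the scatter is expected in this assay, although the range must stay wide without a hydroxy example. The expected step is a 1.1-fold lower number from compound 3 to compound 4 (0.04 log units; within the scatter) by this estimate. For compound 4 the estimated value is 22000 nM (expected range 9000 nM to 50000 nM).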

Compound 4, half-maximal inhibitory concentration: 19300 nM
Estimate against measurement, compound 4: 1.1-fold (0.06 log units) above, within the range that was stated.
By their numbers in this assay, from the lowest: compounds 2, 4, 3 and 1 (each within the scatter of the next, the first and the last beyond it).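

In this assay, hydroxy on this aromatic carbon, meta to a large group, adds a hydrogen-bond donor and a hydrogen-bond acceptor that bromo lacks, yet the number moves only within the scatter (a 1.2-fold lower number from compound 3 to compound 4 (0.09 log units; within the scatter)). The 3-hydroxyphenyl compound also stays within the scatter of the 4-chlorophenyl compound (a 1.0-fold higher number from compound 2 to compound 4 (0.02 log units; within the scatter)) but not of the 2-chlorophenyl compound (a 2.3-fold lower number from compound 1 to compound 4 (0.36 log units; beyond the scatter)), so every step beyond the scatter among these four now involves compound 1. No measurement at hand accounts for how little this exchange moves the number.

Going by these compounds, whether an amine or a carboxylic acid on this same carbon would also stay within the scatter remains open. So does whether hydroxy behaves the same way on any other carbon of this ring.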